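Replacing the aryl group of compound 2

The source may report more compounds than this note shows. Statements on the series, on what has been measured and on what is new or still open speak of the compounds shown alone.

In a functional assay (aorta) with Oryctolagus cuniculus as the target (a higher number here means weaker binding, a lower number tighter binding), compound 1 (`COc1cc(C(C)=O)ccc1OCCCN1CCC(Cc2ccc(F)cc2)CC1`) gives 20 nM and compound 2 (`COC(=O)c1ccc(OCCCN2CCC(C(c3ccc(F)cc3)c3ccc(F)cc3)CC2)c(OC)c1`) gives 1.26 nM. Compound 2 therefore holds the lower of the two numbers, and its gap to compound 1 lies beyond the scatter. Compound 3 (`NC(=O)c1ccc(OCCCN2CCC(C(c3ccc(F)cc3)c3ccc(F)cc3)CC2)cc1`) departs from compound 2 through one exchange: 4-carbamoylphenyl in place of 2-methoxy-4-(methoxycarbonyl)phenyl on an oxygen on a saturated carbon. This places 4-carbamoylphenyl where 2-methoxy-4-(methoxycarbonyl)phenyl stood, on an oxygen on a saturated carbon. Within the data shown here, no measured pair tests this exchange, so the expectation remains loose. Among the measured compounds shown here, since compound 2 starts from the lowest number so far, at 1.26 nM, a move toward a higher number in this assay is expected, somewhat beyond the scatter. The expected change is a 4.0-fold higher number from compound 2 to compound 3 (0.60 log units; beyond the scatter). Compound 3 is estimated at 5 nM, with an expected range of 1.5 nM to 20 nM.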

Compound 3, dissociation constant: 31.6 nM
For compound 3 the middle estimate is 6.3-fold (0.80 log units) below the measured one; the whole stated range lies below it.
By their numbers in this assay, from the lowest: compound 2; then compounds 1 and 3 (each within the scatter of the next).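

In this assay, among these compounds, the aryl group on this oxygen is the first single-place change, and it is not neutral: 4-carbamoylphenyl in place of 2-methoxy-4-(methoxycarbonyl)phenyl gives a 25-fold higher number from compound 2 to compound 3 (1.40 log units; beyond the scatter). The exchange alters several features at once, with 12 heavy atoms leaving, 9 entering and a hydrogen-bond donor appearing, and this single step does not separate them. No available data bear on the reason for the step.

On these data alone, it remains open whether the step follows the loss of the methoxy group or the exchange of methoxycarbonyl for carbamoyl. Also open, as far as these compounds go, is how this position reads with a carboxylic acid or a nitrile on the phenyl ring in place of the carbamoyl group.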